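Adding a hydroxy group to compound 3

The source may hold more compounds than are shown below. What is called first, only, known or untested is meant among the compounds shown, and "the series" means these compounds.

Values in a functional assay on A549 cells (Homo sapiens) for antiproliferative activity, read by MTT assay, with a stated time of 48 h (a higher number here means a weaker inhibitor, a lower number a stronger inhibitor), are these
compound 1 `C=C(c1cc(OC)c(OC)c(OC)c1)c1ccc(OC)cc1NC(=O)CO` gives 20 nM
compound 2 `C=C(c1cc(OC)c(OC)c(OC)c1)c1ccc(OC)cc1NC(=O)CNCC` gives 260 nM
compound 3 `C=C(c1cc(OC)c(OC)c(OC)c1)c1ccc(OC)cc1NC(=O)CN(C)C` gives 130 nM

Compound 3 cannot be separated from compound 2 (there is a 2.0-fold lower number from compound 2 to compound 3 (0.30 log units; within the scatter)), and both stand above compound 1 (modest a 6.5-fold higher number from compound 1 to compound 3 (0.81 log units; beyond the scatter) and large a 13-fold higher number from compound 1 to compound 2 (1.11 log units; beyond the scatter)). Compound 4 `C=C(c1cc(OC)c(OC)c(OC)c1)c1ccc(OC)c(O)c1NC(=O)CN(C)C` keeps the dimethylamino chain of compound 3 and places hydroxy in place of hydrogen on an aromatic carbon. All measured steps concern the chain, so none tests this change on the ring. They show that this assay responds to chain changes but give no direction here. The expected result is therefore no step beyond the scatter, though with wide uncertainty (expected is a 1.2-fold higher number from compound 3 to compound 4 (0.06 log units; within the scatter)). Compound 4 is estimated at 150 nM (range 40 nM to 500 nM).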

Compound 4, half-maximal inhibitory concentration: 50 nM
Compound 4: the middle estimate sits 3.0-fold (0.48 log units) above what was measured, within the range that was stated.
By their numbers in this assay, from the lowest: compound 1; then compound 4; then compounds 3 and 2 (each within the scatter of the next).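

In this assay, hydroxy in place of hydrogen on this aromatic carbon, ortho to a methoxy group, gives a 2.6-fold lower number from compound 3 to compound 4 (0.41 log units; beyond the scatter) and so lowers the number with the dimethylamino chain held fixed. This shows that the ring position, and not only the chain, affects the result in this assay. No measurement shown here accounts for the step.

On these data alone, it remains open whether the same change would act similarly with the hydroxy chain of compound 1 or the ethylamino chain of compound 2. Also open, as far as these compounds go, is how an amine or a fluorine on this carbon would compare.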